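A few compounds are considered here, and "the series" means these few. Any claim that something is new, unique, unknown or untested is made for them only; others in the source may bear on it.

Of the compounds shown here, three have so far been measured in a functional assay on MGC-803 cells (Homo sapiens) for inhibition, read by MTT assay, with a stated time of 72 h; a lower number here means a stronger inhibitor, a higher number a weaker inhibitor. Compound 1 `O=C(CSc1nc(Nc2ccccc2)c2ccccc2n1)Nc1ccccc1Br` gives 18600 nM, compound 2 `CCc1cccc(NC(=O)CSc2nc(Nc3ccccc3)c3ccccc3n2)c1` gives 15800 nM, and compound 3 `C=CC(=O)Nc1cccc(NC(=O)CSc2nc(Nc3ccccc3Br)c3ccccc3n2)c1` gives 12800 nM. Compound 3 has the lowest of the three numbers, yet its gaps to compound 2 and to compound 1 both lie within the scatter, so no order among the three can be read from these values. Among the compounds with values here, the only step between measured compounds that differ in one place runs a 1.2-fold lower number from compound 1 to compound 2 (0.07 log units; within the scatter); it sits on an amide-type nitrogen and stayed within the scatter.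

Compound 4 `C=CC(=O)Nc1cccc(NC(=O)CSc2nc(Nc3ccc(Cl)cc3Cl)c3ccccc3n2)c1` differs from compound 3 in one place: 2,4-dichlorophenyl in place of 2-bromophenyl on a nitrogen on an aromatic ring. Within the data shown here, no measured pair changes the group on that nitrogen, so the step from compound 1 to compound 2 bears on it only loosely, as a sign that exchanging one substituted phenyl for another elsewhere on the shared core changed little. The expected step is therefore a 1.1-fold lower number from compound 3 to compound 4 (0.03 log units; within the scatter), meaning no change beyond the scatter is anticipated. Compound 4 is estimated at 12000 nM, in a range from 5000 nM to 30000 nM.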

Compound 4, half-maximal inhibitory concentration: 12100 nM
Estimate against measurement, compound 4: 1.0-fold (0.00 log units) below; the measured number falls inside the stated range.
By their numbers in this assay, from the lowest: compounds 4, 3, 2 and 1 (each within the scatter of the next).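

Within the data shown here, this is the first measured change to the group on a nitrogen on an aromatic ring: in this assay, 2,4-dichlorophenyl in place of 2-bromophenyl gives a 1.1-fold lower number from compound 3 to compound 4 (0.02 log units; within the scatter) and so leaves the two numbers indistinguishable. At this position, then, one halogen-bearing phenyl group can replace the other without a difference that this assay can separate from ordinary repeat variation. No measurement is available that would explain this result.

Both groups compared here are phenyl rings carrying bromine or chlorine, so this single step cannot show how far the position tolerates other kinds of group. Going by these compounds, whether a pyridine ring, or a phenyl ring carrying an amine or a carboxylic acid, would move the number beyond the scatter remains open.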